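A few compounds are considered here, and "the series" means these few. Any claim that something is new, unique, unknown or untested is made for them only; others in the source may bear on it.

Compound 1 `C[N+]1(C)C[C@@H](c2ccccc2)[C@H](c2nc3ccc(-c4cn[nH]c4)cc3c(=O)[nH]2)C1`: 4 nM
Compound 2 `Cc1n[nH]cc1-c1ccc2nc([C@@H]3CNC[C@H]3c3ccccc3)[nH]c(=O)c2c1`: 7 nM

Of the compounds shown here, two have been measured in an in vitro assay on Sf9 cells for inhibition of Rho-associated protein kinase 2 (Homo sapiens), read by TR-FRET, with a stated time of 25 min; on this read-out higher numbers stand for weaker inhibition and lower numbers for stronger inhibition. Compound 1 gives 4 nM, and compound 2 gives 7 nM. Among the measured compounds shown here, compound 2 has the higher of the two numbers, but its nearest neighbour, compound 1, lies within the usual scatter of repeated measurements, so the two cannot be told apart on this evidence; no step between measured compounds has been worked out.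

Compound 3 `Nc1nccc(-c2ccc3nc([C@@H]4CNC[C@H]4c4ccccc4)[nH]c(=O)c3c2)n1` is the next compound and has not yet been measured. For the measured compounds named here, it keeps the shared core and the pyrrolidine-linked phenyl of compound 2 and changes only one group: 2-aminopyrimidin-4-yl in place of 3-methyl-1H-pyrazol-4-yl on an aromatic carbon. Going by the values given here, no measured pair shows what such an exchange does in this assay, so the expectation for compound 3 rests on compound 2 alone and on the fact that both measured compounds sit close together. A modest move toward a higher number is expected, a step of about a 2.1-fold higher number from compound 2 to compound 3 (0.33 log units; beyond the scatter), although a result within the scatter would not be surprising. Compound 3 is therefore estimated at 15 nM, with a likely range from 4 nM to 60 nM.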

Compound 3, half-maximal inhibitory concentration: 6 nM
The estimate for compound 3 lay 2.5-fold (0.40 log units) above the measured number; the measured number falls inside the stated range.
By their numbers in this assay, from the lowest: compounds 1, 3 and 2 (each within the scatter of the next).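

In this assay the exchange of 3-methyl-1H-pyrazol-4-yl for 2-aminopyrimidin-4-yl on this aromatic carbon gives a 1.2-fold lower number from compound 2 to compound 3 (0.07 log units; within the scatter) and so leaves the two compounds indistinguishable. Among the compounds shown here, this is the first direct comparison at this position, and it shows that, for this pair, a six-membered aromatic ring with 3 hydrogen-bond acceptors can stand in place of a five-membered aromatic ring with 1 hydrogen-bond acceptor without a measurable change in the read-out. No independent measurement is available to explain this result.

From the compounds shown here alone, this single pair cannot show how far the position tolerates change, so the effect of a plain phenyl ring, a pyrimidin-4-yl without the amino group, or a small group with no ring, such as a methoxy group, remains open. Going by these compounds, it is also open whether 2-aminopyrimidin-4-yl would give a similar number on the core of compound 1, which carries a permanently charged dimethylammonium nitrogen in its saturated ring.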